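A few compounds are considered here, and "the series" means these few. Any claim that something is new, unique, unknown or untested is made for them only; others in the source may bear on it.

Compound 3, `COC1=C(C)C(=O)/C(=C(O)/C=C/c2c(C)cccc2C)C(=O)C1(C)C`, is known in a functional assay on HUVEC cells (Homo sapiens) (a lower number here means that less compound is needed, a higher number that more compound is needed for the effect), only through a limit: in this assay compound 3 gives < 4 ug/mL, which is a limit of the assay and not a number. The same holds for its neighbours. Compound 1, `COC1=C(C)C(=O)/C(=C(O)/C=C/c2ccc(OC)cc2)C(=O)C1(C)C`, gives in this assay < 4 ug/mL, a limit. Compound 2, `COC1=C(C)C(=O)/C(=C(O)/C=C/c2ccc(C)cc2)C(=O)C1(C)C`, gives in this assay < 4 ug/mL, again a limit. Accordingly the three steps among them cannot be read: a step that the two limits leave unreadable from compound 1 to compound 2, a step that the two limits leave unreadable from compound 1 to compound 3 and a step that the two limits leave unreadable from compound 2 to compound 3. What the numbers do show is summed up in one observation: the limit of < 4 ug/mL in this assay, at which 3 of the 3 values shown sit.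

Compound 4 is `COC1=C(C)C(=O)/C(=C(O)/C=C/c2ccco2)C(=O)C1(C)C`. It differs from compound 3 in one place: furan-2-yl in place of 2,6-dimethylphenyl on a double-bonded chain carbon bound to a double-bonded chain carbon. For the measured compounds named here, no measured step bears on this change with a readable size, so neither direction nor magnitude can be drawn from them; the expected step that the limit leaves unreadable from compound 3 to compound 4 is therefore set close to nothing beyond the scatter. Compound 4 is estimated to give 2.5 ug/mL in this assay, with a range from 0.5 ug/mL to 10 ug/mL.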

Compound 4, concentration for half-maximal effect: < 4 ug/mL
Compound 4: a limit, no number; the forecaster's own chance of this, stated with the estimate: 60%; the middle value lies beyond the limit too.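

In this assay compound 4 gives < 4 ug/mL, a limit and not a number. The steps linking compound 4 to compound 1, compound 2 and compound 3 therefore cannot be read. The compounds shown leave open whether these four differ at all in this assay, and by how much: the limit of < 4 ug/mL in this assay, at which 4 of the 4 values shown sit.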